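A few compounds are considered here, and "the series" means these few. Any claim that something is new, unique, unknown or untested is made for them only; others in the source may bear on it.

Two close relatives give a first view of this series. Among the measured compounds shown here, in a functional assay on HeLa cells (Homo sapiens) for cytotoxicity, read by MTT assay, with a stated time of 48 h (a lower number here means a stronger inhibitor, a higher number a weaker inhibitor), compound 1 `N#Cc1ccc(Cn2c(/C=C3\SC(=S)N(CC(=O)O)C3=O)nc3ccccc32)cc1`, which carries a 4-cyanobenzyl group, gives 16300 nM, the higher of the two numbers so far and so the weaker inhibitor of the pair. Compound 2 `Cc1ccc(Cn2c(/C=C3\SC(=S)N(CC(=O)O)C3=O)nc3ccccc32)cc1`, with methyl in place of cyano on an aromatic carbon, gives 1280 nM. For the measured compounds named here, this swap is the only measured step, and it reads a 13-fold lower number from compound 1 to compound 2 (1.10 log units; beyond the scatter), a large change beyond the scatter of repeat measurements.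

Compound 3 `O=C(O)CN1C(=O)/C(=C/c2nc3ccccc3n2Cc2ccc(Cl)cc2)SC1=S` keeps the rest of compound 1 and alters the same group: chloro in place of cyano on an aromatic carbon. Here the 4-cyanobenzyl group of compound 1 becomes a 4-chlorobenzyl group. Compound 2 also loses the cyano, so its step is the best available guide, and a move toward a lower number in this assay is expected. Yet chloro is not methyl, and no measured compound carries chloro, so the guide is thin. The expected change is a 6.5-fold lower number from compound 1 to compound 3 (0.81 log units; beyond the scatter). For compound 3 the estimated value is 2500 nM, with an expected range from 700 nM to 8000 nM.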

Compound 3, half-maximal inhibitory concentration: 8720 nM
Compound 3: middle estimate off by 3.5-fold (0.54 log units), on the low side, and the stated range ends below it.
By their numbers in this assay, from the lowest: compound 2; then compounds 3 and 1 (each within the scatter of the next).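

In this assay the loss of the cyano group does not by itself bring the lower number seen with methyl: chloro in place of cyano reads a 1.9-fold lower number from compound 1 to compound 3 (0.27 log units; within the scatter), so compound 3 and compound 1 cannot be told apart in this assay. Set against methyl at the same place, chloro reads a 6.8-fold higher number from compound 2 to compound 3 (0.83 log units; beyond the scatter), which leaves compound 2 apart from both of the others. The large step seen earlier therefore looks tied to methyl entering at this position on the benzyl group, rather than to cyano simply leaving, although three compounds can support this reading only for these three groups. No evidence at hand speaks to what lies behind this difference.

The compounds shown leave open whether the standing of compound 2 is particular to methyl or would also hold for an ethyl, a methoxy or a trifluoromethyl group at this place. They also leave open how an amine or a hydroxyl group would read here, and whether methyl would give a similar step at another carbon of the same ring.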